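The source may report more compounds than this note shows. Statements on the series, on what has been measured and on what is new or still open speak of the compounds shown alone.

Measured so far:
compound 1 `C=CCNC(=O)n1c(-c2ccc(OC)cc2)cc(=O)c2c(OC)cc(OC)cc21` — 12000 nM
compound 2 `COc1ccc(-c2c(I)c(=O)c3c(OC)cc(OC)cc3n2S(=O)(=O)c2ccc(OC)cc2)cc1` — 8580 nM
compound 3 `COC(=O)c1cc(=O)c2cc(N)ccc2[nH]1` — a limit, > 33700 nM

The three compounds were tested in a functional assay on KOPN-8 cells (Homo sapiens) for antiproliferative activity, with a stated time of 72 h; on this read-out lower numbers stand for an effect already at smaller amounts and higher numbers for an effect only at larger amounts of compound. Compound 1 gives 12000 nM and stands at the higher of the two numbers obtained; compound 2 gives 8580 nM, and the two values lie within the usual scatter of each other, so no order can be read between them. Compound 3 reaches only the limit of the assay, > 33700 nM; of the three values shown, one sits at this limit (the limit of > 33700 nM in this assay, at which 1 of the 3 values shown sits).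

The account now turns to compound 4 `COc1ccc(-c2cc(=O)c3c(OC)cc(OC)cc3n2S(=O)(=O)c2ccc(Cl)cc2)cc1`, not yet measured in this assay. It differs from compound 1 in one place: (4-chlorophenyl)sulfonyl in place of allylcarbamoyl on an aromatic nitrogen. Among the compounds with values here, no pair of measured compounds differs in exactly this way, so no measured step can be pointed to. The closest guide is that compound 2 also gives a value within the scatter of compound 1. Compound 4 is therefore expected to give about 8000 nM, within a range from 2500 nM to 25000 nM. The estimated step of a 1.5-fold lower number from compound 1 to compound 4 (0.18 log units; within the scatter) is expected to stay within the scatter, with no clear direction.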

Compound 4, half-maximal effective concentration: > 34400 nM
Compound 4: a limit, no number; the forecaster's own chance of this, stated with the estimate: 15%; middle value at least 4.3-fold (0.63 log units) away from the limit.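

In this assay, (4-chlorophenyl)sulfonyl in place of allylcarbamoyl on an aromatic nitrogen gives an at least 2.8-fold higher number from compound 1 to compound 4 (0.45 log units; beyond the scatter). Within the data shown here, this is the first one-place comparison, and it shows that the read-out responds to the group on this nitrogen. Compound 4 stands at a limit of the assay and not at a number, so the size of the step stays open at its upper end: the limit of > 34400 nM in this assay, at which 1 of the 4 values shown sits.

The compounds shown leave open whether the change in the read-out goes with the sulfonyl link or with the 4-chlorophenyl ring, which a methylsulfonyl group or a plain phenylsulfonyl group on the same nitrogen would help to separate. They also leave open what a longer chain in place of the allyl of the carbamoyl group, or an amine at its end, would do to the value of compound 1.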